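A few compounds are considered here, and "the series" means these few. Any claim that something is new, unique, unknown or untested is made for them only; others in the source may bear on it.

Measured compounds:
- Compound 1, `COc1cc2cc(C(=O)NCc3ccc(F)cc3)c(=O)oc2cc1OCCCOc1no[n+]([O-])c1S(=O)(=O)c1ccccc1`, gives 370 nM in a functional assay on MCF7 cells (Homo sapiens) for inhibition, read by MTT assay, with a stated time of 48 h; on this read-out lower numbers stand for stronger inhibition and higher numbers for weaker inhibition.
- Compound 2, `COc1ccc(CNC(=O)c2cc3cc(OC)c(OCCCOc4no[n+]([O-])c4S(=O)(=O)c4ccccc4)cc3oc2=O)cc1`, gives 560 nM in this assay.
- Compound 3, `COc1cc2cc(C(=O)NCCCc3ccc(F)cc3)c(=O)oc2cc1OCCCOc1no[n+]([O-])c1S(=O)(=O)c1ccccc1`, gives 600 nM in this assay.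

Compound 1 has the lowest of the three numbers, but both of its neighbours sit close: a 1.5-fold higher number from compound 1 to compound 2 (0.18 log units; within the scatter) and a 1.6-fold higher number from compound 1 to compound 3 (0.21 log units; within the scatter), so no order among the three can be claimed.

Compound 4, `COc1cc2cc(C(=O)NCc3ccccc3)c(=O)oc2cc1OCCCOc1no[n+]([O-])c1S(=O)(=O)c1ccccc1`, differs from compound 1 in one place: hydrogen in place of fluoro on an aromatic carbon. The most relevant comparison is the step from compound 1 to compound 2, which also exchanged the fluoro on that aromatic carbon for another group, and gave a 1.5-fold higher number from compound 1 to compound 2 (0.18 log units; within the scatter). Nothing measured here points to a change beyond the scatter when the fluoro is simply removed.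

Compound 4 is therefore expected to give about 450 nM in this assay, with a likely range from 220 nM to 900 nM. That estimate means a 1.2-fold higher number from compound 1 to compound 4 (0.09 log units; within the scatter), a step expected to stay within the scatter.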

Compound 4, half-maximal inhibitory concentration: 740 nM
Beside the measured number, compound 4's estimate is 1.6-fold (0.22 log units) below it; the measured number falls inside the stated range.
By their numbers in this assay, from the lowest: compounds 1, 2, 3 and 4 (each within the scatter of the next).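

Taking the fluoro off the 4-fluorophenyl group of compound 1 leaves a plain phenyl ring, and in this assay this gives (a 2.0-fold higher number from compound 1 to compound 4 (0.30 log units; within the scatter)), so the fluoro is not shown to matter for this read-out. Exchanging methoxy for hydrogen on the same aromatic carbon gives (a 1.3-fold higher number from compound 2 to compound 4 (0.12 log units; within the scatter)), and the change of side chain gives (a 1.2-fold higher number from compound 3 to compound 4 (0.09 log units; within the scatter)), which means that hydrogen, fluoro and methoxy at this place cannot be told apart here. No measurement offered here explains these small differences.

From the compounds shown here alone, whether a carboxylic acid or a dimethylamino group on this aromatic carbon would move the number beyond the scatter remains open. The same question stands for a longer chain between the amide nitrogen and an unsubstituted phenyl ring.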